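Compound 4: an Azetidine Returns in Place of a Dimethylamine

This account rests on a few compounds, and the source may have more. Where it says the series, first, only, none or still open, it means among the compounds named here.

compound 1 `CCCCCCCCCCc1ccc(-c2noc(C3CNC3)n2)cc1` — 65%
compound 2 `CCCCCCCCCCc1ccc(-c2noc(CCCN)n2)cc1` — 67%
compound 3 `CCCCCCCCCCc1ccc(-c2noc(CCCN(C)C)n2)cc1` — 8%

Of the compounds shown here, three have been measured in an assay on HeLa cells for inhibition of sphingosine-1-phosphate transporter SPNS2 (Mus musculus), read by LC-MS, tested at 2 uM; a lower number here means less inhibition, a higher number more inhibition at the concentration tested (going by the name of the read-out). Compound 1 gives 65% and compound 2 gives 67%; the step of a number 2 percentage points higher from compound 1 to compound 2 (within the scatter) shows that these two cannot be told apart. Compound 3 gives 8%, the lowest of the three numbers, with compound 1 nearest and compound 2 furthest, both beyond the scatter above it.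

Compound 4 `CCCCCCCCCCc1ccc(-c2noc(CC3CNC3)n2)cc1` has not yet been measured. It differs from compound 3 by azetidin-3-yl in place of 2-(dimethylamino)ethyl on a saturated chain carbon bound to an aromatic carbon. Among the measured compounds shown here, two measured steps bear on this change: a number 57 percentage points lower from compound 1 to compound 3 (beyond the scatter) and a number 59 percentage points lower from compound 2 to compound 3 (beyond the scatter), both large drops, each of them putting a dimethylamino-bearing chain where a group with one hydrogen-bond donor had been. Compound 4 goes the other way, bringing the azetidin-3-yl of compound 1 back one bond further out. A large rise is therefore expected for compound 4 in this assay, roughly a number 52 percentage points higher from compound 3 to compound 4 (beyond the scatter). The estimate for compound 4 is 60%, within a range from 40% to 75%.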

Compound 4, a percentage reported as inhibition, at one concentration (the size of the read-out at that concentration, not a potency): 63%
Compound 4: middle estimate off by 3 percentage points, on the low side, and the stated range covers the measured number.
By their numbers in this assay, from the lowest: compound 3; then compounds 4, 1 and 2 (each within the scatter of the next).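

In this assay the change from 3-(dimethylamino)propyl to (azetidin-3-yl)methyl gives a number 55 percentage points higher from compound 3 to compound 4 (beyond the scatter) and so shows that the low number does not extend to every amine-bearing group at this place. The azetidine ring can also stand one bond further out, since (azetidin-3-yl)methyl in place of azetidin-3-yl gives a number 2 percentage points lower from compound 1 to compound 4 (within the scatter) and the two cannot be told apart. Azetidin-3-yl in place of 2-aminoethyl gives a number 4 percentage points lower from compound 2 to compound 4 (within the scatter) so ring and open chain cannot be told apart here either, and among these four only compound 3 stands apart.

The compounds shown leave open whether the low number goes with the two methyl groups on the nitrogen as such or with the open chain that carries them. A 3-(methylamino)propyl or a (1-methylazetidin-3-yl)methyl group would bear on this question. Nothing measured here accounts for why the numbers fall as they do.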